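The compounds below may be only part of what the source reports. "The series", "measured", "known", "first", "only" and "open" are said of these compounds alone.

Values so far in a physicochemical assay for solubility (a lower number here means a less soluble compound, a higher number a more soluble compound), are:
- compound 1 `CN(C)CC(=O)N1CCC(NS(=O)(=O)c2cc(S(=O)(=O)c3ccccc3)ccc2C(F)(F)F)CC1` gives 100000 nM
- compound 2 `O=C(CN1CCCC1)N1CCC(NS(=O)(=O)c2cc(S(=O)(=O)c3ccccc3)ccc2C(F)(F)F)CC1` gives 25000 nM
- compound 3 `CC(C)C(=O)N1CCC[C@H]1C(=O)N1CCC(NS(=O)(=O)c2cc(S(=O)(=O)c3ccccc3)ccc2C(F)(F)F)CC1` gives 100000 nM

Compound 3 stands level with compound 1 as the highest of these numbers, and compound 2 gives the lowest. Compound 4 `CN(C)c1ccc(C(=O)N2CCC[C@H]2C(=O)N2CCC(NS(=O)(=O)c3cc(S(=O)(=O)c4ccccc4)ccc3C(F)(F)F)CC2)cc1` differs from compound 3 in one place, on a carbonyl carbon bound to an amide-type nitrogen in a ring, where 4-(dimethylamino)phenyl replaces isopropyl 4-(dimethylamino)phenyl in place of isopropyl on a carbonyl carbon and adds an aromatic ring.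

Within the data shown here, no measured step makes this exact change, so the evidence is indirect. Replacing dimethylamino with pyrrolidin-1-yl gave a 4.0-fold lower number from compound 1 to compound 2 (0.60 log units; beyond the scatter), whereas the other two steps gave no change at the digits printed from compound 1 to compound 3 (within the scatter) and a 4.0-fold higher number from compound 2 to compound 3 (0.60 log units; beyond the scatter) as their results. Changes to this part of the molecule have therefore been modest or absent, and they have gone in both directions. Compound 3 already shares the highest number, so a fall seems likelier than a rise. The expected step is a 4.0-fold lower number from compound 3 to compound 4 (0.60 log units; beyond the scatter), a modest fall with real uncertainty. The estimate for compound 4 is 25000 nM, with an expected range from 3000 nM up to 100000 nM in this assay.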

Compound 4, solubility: 100000 nM
Compound 4: the middle estimate sits 4.0-fold (0.60 log units) below what was measured; the range from low to high includes it.
By their numbers in this assay, from the lowest: compound 2; then compounds 1, 3 and 4 (each within the scatter of the next).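

In this assay, among these compounds, the swap of isopropyl for 4-(dimethylamino)phenyl on this carbonyl carbon gave no change at the digits printed from compound 3 to compound 4 (within the scatter), and that is the first look at a large change at this position. The entering group has 9 heavy atoms against 3 for isopropyl and brings a six-membered aromatic ring to a place that held no ring in compound 3, yet the printed number stayed the same. So, for this one pair, the position tolerated a much bigger group without any visible shift, though nothing measured here accounts for that.

Going by these compounds, whether a plain phenyl, with no dimethylamino group, would give the same number in this assay remains open. So does the outcome for a phenyl ring carrying a carboxylic acid, or for a longer alkyl chain on this carbonyl carbon.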